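This account rests on a few compounds, and the source may have more. Where it says the series, first, only, none or still open, it means among the compounds named here.

In a functional assay on NCI-H226 cells (Homo sapiens) for inhibition, read by MTT assay, with a stated time of 48 h, tested at 10 uM (on this read-out higher numbers stand for more inhibition at the one concentration tested (going by the name of the read-out) and lower numbers for less inhibition), compound 3 `COc1cc(NC(=O)Nc2cc(Nc3ccc(F)c(Cl)c3)ncn2)cc(OC)c1` gives 36.7%. Compound 1 `CCc1cccc(Nc2cc(NC(=O)Nc3cc(OC)cc(OC)c3)ncn2)c1` gives 36.7% in this assay, and compound 2 `COc1cc(NC(=O)Nc2cc(Nc3ccc(C)c(F)c3)ncn2)cc(OC)c1` gives 39.7%. Compound 3 stands level with compound 1 at the digits shown, the two together making up the lowest pair of the three numbers; its nearest neighbour is compound 1, with no change at the digits printed from compound 1 to compound 3 (within the scatter), and its furthest is compound 2, with a number 3 percentage points lower from compound 2 to compound 3 (within the scatter), both within the scatter. The third step, a number 3 percentage points higher from compound 1 to compound 2 (within the scatter), is also within the scatter.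

Compound 4 `COc1cc(NC(=O)Nc2cc(Nc3cc(I)ccc3OC)ncn2)cc(OC)c1` differs from compound 3 by 5-iodo-2-methoxyphenyl in place of 3-chloro-4-fluorophenyl on a nitrogen on an aromatic ring. Every measured step in this series swaps the aryl group on that same nitrogen, and none of them moved the read-out beyond the scatter. Compound 4 is therefore expected to sit close to compound 3, with an estimated step of a number 0.3 percentage points higher from compound 3 to compound 4 (within the scatter). The estimate for compound 4 in this assay is 37%, expected to fall between 22% and 52%.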

Compound 4, a percentage reported as inhibition, at one concentration (the size of the read-out at that concentration, not a potency): 56.7%
Beside the measured number, compound 4's estimate is 19.7 percentage points below it, and the stated range ends below it.
By their numbers in this assay, from the lowest: compounds 1, 3 and 2 (each within the scatter of the next); then compound 4.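

In this assay the aryl group on this nitrogen turns out to matter, which the earlier swaps did not show: 5-iodo-2-methoxyphenyl gives (a number 20 percentage points higher from compound 3 to compound 4 (beyond the scatter)), and the same change gives (a number 17 percentage points higher from compound 2 to compound 4 (beyond the scatter)) and (a number 20 percentage points higher from compound 1 to compound 4 (beyond the scatter)). Compound 4 therefore stands apart from all three earlier compounds, while 3-ethylphenyl, 3-fluoro-4-methylphenyl and 3-chloro-4-fluorophenyl remain within the scatter of one another. No measurement at hand accounts for the rise.

The iodine and the methoxy enter together in compound 4, so the compounds shown cannot assign the rise to either one or to the pair. They also leave open whether the number would be higher, lower or level with an aryl group carrying an amine or a carboxylic acid on this nitrogen.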